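This account rests on a few compounds, and the source may have more. Where it says the series, first, only, none or still open, it means among the compounds named here.

Compound 1 `COc1ccc(F)cc1CNCCCNc1ccnc2cc(C3CCCCC3)ccc12` is measured in a physicochemical assay for acid dissociation, where compound 1 gives 9.47. Compound 2 `Fc1ccc(Cc2ccc3c(NCCCNCc4ccco4)ccnc3c2)c(Cl)c1` gives 9.47 in this assay, so compound 1 stands level with compound 2 at the digits shown, within the scatter. Compound 3 `COc1ccc(F)cc1CNCCCNc1ccnc2cc(-c3cccc4ccccc34)ccc12` differs from compound 1 by naphthalen-1-yl in place of cyclohexyl on an aromatic carbon, a change on the shared core. No step of this kind has been measured among these compounds, and since the change leaves the two amine nitrogens untouched, the expected step is a number 0.02 log units lower from compound 1 to compound 3 (within the scatter), none beyond the scatter. Compound 3 is therefore estimated to give 9.45, with a range from 9.1 to 9.8.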

Compound 3, acid dissociation constant: 9.47
Beside the measured number, compound 3's estimate is 0.02 log units below it; low and high end bracket the measured number.
By their numbers in this assay, from the lowest: compounds 1, 2 and 3 (each within the scatter of the next).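

Within this assay, placing naphthalen-1-yl in place of cyclohexyl on an aromatic carbon brings no change at the digits printed from compound 1 to compound 3 (within the scatter) at this position on the shared core. A non-aromatic ring can thus give way to two aromatic rings here without moving this read-out beyond the scatter; both groups are carbon only, with no hydrogen-bond donors or acceptors and no net charge. Nothing measured here accounts for this result. Still open, on these data alone, is how this read-out responds when this position carries an amine or a carboxylic acid.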